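Hydroxy to methoxy: working notes on the series

The compounds below may be only part of what the source reports. "The series", "measured", "known", "first", "only" and "open" are said of these compounds alone.

compound 1 `COc1ccc(/C=C/C(=O)c2ccc(N)c(-c3ccc(F)cc3)c2)cc1O` reads "not determined" (no result reported)
compound 2 `COc1cc(/C=C/C(=O)c2cccc(-c3cccc(F)c3)c2)ccc1O` gives 5690 nM
compound 3 `COc1ccc(/C=C/C(=O)c2cccc(-c3cccc(F)c3)c2)cc1O` reads "not determined" (no result reported)
compound 4 `COc1ccc(/C=C/C(=O)c2cccc(-c3cccc(F)c3)c2)cc1OC` is still to be measured

In a functional assay on CNE-2 cells (Homo sapiens) for cytotoxicity, read by sulforhodamine B assay, with a stated time of 48 h (on this read-out higher numbers stand for weaker inhibition and lower numbers for stronger inhibition), compound 3 has no single number, and compound 1 is no different on that score. The step methyl in place of hydrogen on an oxygen on an aromatic ring places methyl in place of hydrogen on an oxygen on an aromatic ring, hydroxy to methoxy. Among the compounds with values here, no measured step exists for this change, so its size cannot be read from the series. In this assay a small step toward weaker inhibition is expected, not far beyond the usual scatter. Within the data shown here, the only available anchor is compound 2 at 5690 nM in this series. For compound 4 the estimated value is 8000 nM with an expected range from 2500 nM to 25000 nM for now.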

Compound 4, half-maximal inhibitory concentration: 770 nM
Compound 4: middle estimate off by 10-fold (1.02 log units), on the high side; measured number below the stated range.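

In this assay, methyl in place of hydrogen on an oxygen on an aromatic ring now has a size: a 7.4-fold lower number from compound 2 to compound 4 (0.87 log units; beyond the scatter), toward stronger inhibition, so hydroxy to methoxy at this oxygen is no minor change in the series. The corresponding steps from compound 1 and compound 3 cannot be read. Nothing at hand accounts for the size of this step.

The compounds shown leave open whether the stronger inhibition is specific to methoxy at this position. An ethoxy group or a longer chain on the same oxygen could still hold it or lose it.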